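This account rests on a few compounds, and the source may have more. Where it says the series, first, only, none or still open, it means among the compounds named here.

Compound 1 `Cc1ccc(NC2=CC(=O)c3nc4n(c3C2=O)[C@H]2OC[C@@H](O)[C@H]2OC4)cc1` holds the lowest number of the three measured in a functional assay on MCF7 cells (Homo sapiens) for inhibition, read by sulforhodamine B assay (a lower number here means a stronger inhibitor, a higher number a weaker inhibitor), where compound 1 gives 1660 nM. Its nearest neighbour is compound 2 `COc1cccc(NC2=CC(=O)c3c(nc4n3[C@H]3OC[C@@H](O)[C@H]3OC4)C2=O)c1`, which in this assay gives 3830 nM, and furthest is compound 3 `COc1ccc(NC2=CC(=O)c3c(nc4n3[C@H]3OC[C@@H](O)[C@H]3OC4)C2=O)cc1`, which gives 4470 nM; both of those steps from compound 1 lie beyond the scatter. Within the data shown here, the single measured step, a 1.2-fold higher number from compound 2 to compound 3 (0.07 log units; within the scatter), shows that 3-methoxyphenyl and 4-methoxyphenyl give numbers within the scatter of each other. Compound 4 `COc1ccccc1NC1=CC(=O)c2nc3n(c2C1=O)[C@H]1OC[C@@H](O)[C@H]1OC3` differs from compound 1 as follows: 2-methoxyphenyl in place of 4-methylphenyl on an amine nitrogen. Among the measured compounds shown here, no measured step matches this change directly, since the methylphenyl of compound 1 and the methoxyphenyl groups of compounds 2 and 3 are never compared in a single step. Still, both methoxyphenyl compounds return higher numbers than compound 1, and where the methoxy group sits made no difference beyond the scatter. Compound 4 is therefore expected to give a higher number, a 1.9-fold higher number from compound 1 to compound 4 (0.29 log units; within the scatter). In this assay compound 4 is estimated at 3200 nM, with a range of 1300 nM to 8000 nM.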

Compound 4, half-maximal inhibitory concentration: > 4000 nM
Compound 4 ended at the assay's limit; the forecaster's own chance of this, stated with the estimate: 3%; middle value at least 1.2-fold (0.09 log units) away from the limit.
By their numbers in this assay, from the lowest: compound 1; then compounds 2 and 3 (each within the scatter of the next).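

In this assay compound 4 gives > 4000 nM, which is a limit of the assay and not a number: the limit of > 4000 nM in this assay, at which 1 of the 4 values shown sits. Even so, 2-methoxyphenyl in place of 4-methylphenyl on this amine nitrogen can be read as a step, an at least 2.4-fold higher number from compound 1 to compound 4 (0.38 log units; beyond the scatter), so one direct change at this position now lies beyond the scatter, whereas the earlier step between two methoxyphenyl groups stayed within it. The limit gives no order for compound 4 against compound 2 or compound 3, and those steps cannot be read.

The compounds shown leave open whether the lower number of compound 1 goes with the methyl group itself or with where it sits, a question that a 2-methylphenyl or a 3-methylphenyl group would address. From the compounds shown here alone, how an unsubstituted phenyl, a 4-chlorophenyl or an alkyl chain on the same nitrogen would compare also remains open.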